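Aryl swap on the shared core: thiophene for aminophenyl

This account rests on a few compounds, and the source may have more. Where it says the series, first, only, none or still open, it means among the compounds named here.

Working notes on a small set sharing one core. Compound 1 `Cc1ccccc1-c1nnc(SCCn2c([N+](=O)[O-])cnc2C)o1` gives 32300 nM in a functional assay on SGC-7901 cells (Homo sapiens) for cytotoxicity, read by MTT assay, with a stated time of 48 h; on this read-out higher numbers stand for weaker inhibition and lower numbers for stronger inhibition. Compound 2 `Cc1ncc([N+](=O)[O-])n1CCSc1nnc(-c2ccc(N)cc2)o1` gives 31700 nM, the lowest number of the three, though its separation from the other two is within the scatter. Compound 3 `Cc1ncc([N+](=O)[O-])n1CCSc1nnc(-c2ccc(N(C)C)cc2)o1` gives 32800 nM. The step of a 1.0-fold lower number from compound 1 to compound 2 (0.01 log units; within the scatter) and the step of a 1.0-fold higher number from compound 2 to compound 3 (0.01 log units; within the scatter) both leave the read-out where it was.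

Compound 4 `Cc1ncc([N+](=O)[O-])n1CCSc1nnc(-c2cccs2)o1` is not yet measured. Its change from compound 2 is thiophen-2-yl in place of 4-aminophenyl on an aromatic carbon. The two measured steps bear on it only in that each also exchanges the group on the same aromatic carbon of the core, and each was flat. Nothing measured here speaks to a thiophen-2-yl group directly. On that basis no step beyond the scatter is expected, in either direction.

Compound 4 is therefore estimated at 32000 nM, with a range from 16000 nM to 64000 nM. The expected step is a 1.0-fold higher number from compound 2 to compound 4 (0.00 log units; within the scatter).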

Compound 4, half-maximal inhibitory concentration: 30800 nM
Beside the measured number, compound 4's estimate is 1.0-fold (0.02 log units) above it, within the range that was stated.
By their numbers in this assay, from the lowest: compounds 4, 2, 1 and 3 (each within the scatter of the next).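

The earlier steps shown here only exchanged one substituted phenyl group for another, whereas thiophen-2-yl brings a different ring to this aromatic carbon, one five-membered aromatic ring with 1 hetero atom, and this assay shows only a 1.0-fold lower number from compound 2 to compound 4 (0.01 log units; within the scatter) for that exchange. Set against the 2-methylphenyl group, the same ring gives a 1.0-fold lower number from compound 1 to compound 4 (0.02 log units; within the scatter) in this assay as well. Going from 7 to 5 heavy atoms and from 1 hydrogen-bond donor to 0 therefore brings no step beyond the scatter, and no independent evidence accounts for this result.

Going by these compounds, whether a carboxylic acid or a morpholine ring on this carbon would give a step beyond the scatter stays open. So does whether these values depend on the aryl group at all or are set by the rest of the shared core, such as its nitro group or its sulfur-linked chain.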